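Working notes: methyl for trifluoromethyl, compound 3 to compound 4

The source may hold more compounds than are shown below. What is called first, only, known or untested is meant among the compounds shown, and "the series" means these compounds.

compound 1 `COc1ccc(Cl)cc1Cn1c(C(=O)NCC(C)(C)CO)cc2cc(C#N)ccc21` gives 10 mL.min-1.g-1
compound 2 `COc1ccc(C)cc1Cn1c(C(=O)NCC(C)(C)CO)cc2cc(C#N)ccc21` gives 23 mL.min-1.g-1
compound 3 `Cc1ccc(C(F)(F)F)cc1Cn1c(C(=O)NCC(C)(C)CO)cc2cc(C#N)ccc21` gives 16 mL.min-1.g-1

In an in vitro ADME assay on microsomes from liver (Homo sapiens) for metabolic stability, in the presence of a further agent that is not named here (on this read-out higher numbers stand for fast clearance and lower numbers for slow clearance), compound 3 gives 16 mL.min-1.g-1 and lies within the scatter of both compound 1 and compound 2, although those two stand apart beyond the scatter. The move to compound 4 `Cc1ccc(C)c(Cn2c(C(=O)NCC(C)(C)CO)cc3cc(C#N)ccc32)c1` is methyl in place of trifluoromethyl on an aromatic carbon and amounts to methyl in place of trifluoromethyl on an aromatic carbon. Going by the values given here, the only measured step in which methyl enters on an aromatic carbon is a 2.3-fold higher number from compound 1 to compound 2 (0.36 log units; beyond the scatter) and it is modest. Among the compounds with values here, there chloro leaves, not trifluoromethyl, and no measured step shows trifluoromethyl leaving, so this guide is indirect. Its direction is carried over, at a smaller size and with a wide margin. The expected change is a 1.5-fold higher number from compound 3 to compound 4 (0.18 log units; within the scatter) and no more than modest in size. For compound 4 the estimate is 24 mL.min-1.g-1 with an expected range from 13 mL.min-1.g-1 to 42 mL.min-1.g-1 on this read-out.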

Compound 4, intrinsic clearance in microsomes: 29 mL.min-1.g-1
Compound 4: middle estimate off by 1.2-fold (0.08 log units), on the low side, and the stated range covers the measured number.
By their numbers in this assay, from the lowest: compounds 1, 3, 2 and 4 (each within the scatter of the next, the first and the last beyond it).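

In this assay, the direct swap of trifluoromethyl for methyl at this place, meta to a large group and para to a methyl group, gives a 1.8-fold higher number from compound 3 to compound 4 (0.26 log units; within the scatter) and so does not separate the pair. Methyl in place of methoxy also stays inside the scatter, with a 1.3-fold higher number from compound 2 to compound 4 (0.10 log units; within the scatter) as its step, whereas 2,5-dimethylphenyl in place of 5-chloro-2-methoxyphenyl gives a 2.9-fold higher number from compound 1 to compound 4 (0.46 log units; beyond the scatter) and is the only one of these three steps to pass beyond it. No measurement on hand accounts for the size of any of these steps.

Still open, on these data alone, is how this assay would read with an amine or a carboxylic acid at this place rather than methyl or trifluoromethyl. As far as these compounds go, the amide side chain and the nitrile are the same in all four compounds, so their share in these numbers also remains open.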